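A few compounds are considered here, and "the series" means these few. Any claim that something is new, unique, unknown or untested is made for them only; others in the source may bear on it.

Two compounds of the series have been run so far in an ADME assay on MT4 cells (Homo sapiens) for cytotoxicity, read by MTT assay, with a stated time of 5 days; a higher number here means that more compound is tolerated, a lower number that less compound is tolerated. Compound 1 `COc1ccc(NC(=O)CSc2nc(Nc3c(C)cc(/C=C/C#N)cc3C)c3cc(OC)c(OC)cc3n2)cc1` gives only a limit of the assay, > 225000 nM, so no number is available for it. Compound 2 `COc1cc2nc([S+]([O-])CC(=O)Nc3ccccc3F)nc(Nc3c(Cl)cc(/C=C/C#N)cc3Cl)c2cc1OC` likewise reaches only a limit, > 208000 nM, and no number follows from it. Compound 2 therefore stands at the ceiling of what this assay reports, a position it shares with the other value shown: the limit of > 208000 nM in this assay, at which 1 of the 2 values shown sits, and (the limit of > 225000 nM in this assay, at which 1 of the 2 values shown sits). Within the data shown here, no step between measured compounds that differ in one place exists here, so nothing on the size of any structural change in this assay has yet been measured.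

Compound 3 `COc1cccc(NC(=O)C[S+]([O-])c2nc(Nc3c(Cl)cc(/C=C/C#N)cc3Cl)c3cc(OC)c(OC)cc3n2)c1` is the next entry and differs from compound 2 in one place: 3-methoxyphenyl in place of 2-fluorophenyl on an amide-type nitrogen. The amide-type nitrogen that carries the new ring keeps its carbonyl neighbour. With both measured compounds sitting at a limit, no direction can be read from the data. The change a step that the limit leaves unreadable from compound 2 to compound 3 is expected to stay within the scatter, with a limit again the likeliest outcome. Compound 3 is estimated at 210000 nM in this assay, in a range from 100000 nM to 300000 nM.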

Compound 3, half-maximal cytotoxic concentration: >= 167000 nM
Compound 3 gave a limit, no number; the forecaster's own chance of this, stated with the estimate: 85%; the middle value does not contradict the limit.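

Compound 3 in this assay gives only a limit of >= 167000 nM and no number. Among these compounds, with compound 2 also at a limit, no step from compound 2 to compound 3 can be read. Open remains the concentration at which compound 1, compound 2 or compound 3 reaches half-maximal cytotoxicity, and whether 3-methoxyphenyl in place of 2-fluorophenyl shifts it.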